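The source may hold more compounds than are shown below. What is called first, only, known or untested is meant among the compounds shown, and "the series" means these compounds.

In a functional assay on HEK293 cells for antagonist activity at transient receptor potential cation channel subfamily V member 1 (Rattus norvegicus) (on this read-out higher numbers stand for weaker inhibition and lower numbers for stronger inhibition), compound 3 `CCCCc1ccc(NC(=O)N2CCN(c3ncccc3Cl)CC2)cc1` gives 117 nM, the highest number in the set. Compound 2 `CC(C)c1ccc(NC(=O)N2CCN(c3ncccc3C(F)F)CC2)cc1` gives 27.7 nM in this assay, and compound 1 `CC(C)(C)c1ccc(NC(=O)N2CCN(c3ncccc3C(F)(F)F)CC2)cc1` gives 11.3 nM; both lie well under compound 3, which is thus the weakest inhibitor of the three measured. Compound 4 `O=C(Nc1ccc([N+](=O)[O-])cc1)N1CCN(c2ncccc2Cl)CC1` is not yet measured. It differs from compound 3 in one place: nitro in place of butyl on an aromatic carbon. Within the data shown here, no measured pair isolates this change, so the step is uncertain. Compound 3 already stands at 117 nM with a butyl at that aromatic carbon. A nitro there is expected to raise the number further, a moderate step of a 2.6-fold higher number from compound 3 to compound 4 (0.41 log units; beyond the scatter) that may reach beyond the scatter. Compound 4 is therefore estimated at 300 nM, with a range from 80 nM to 1500 nM.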

Compound 4, half-maximal inhibitory concentration: 1110 nM
Compound 4: middle estimate off by 3.7-fold (0.57 log units), on the low side, and the stated range covers the measured number.
By their numbers in this assay, from the lowest: compound 1; then compound 2; then compound 3; then compound 4.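

On an aromatic carbon para to a large group, nitro in place of butyl gives a 9.5-fold higher number from compound 3 to compound 4 (0.98 log units; beyond the scatter) in this assay. This first single-place step in the series shows that the number at this position depends strongly on the group carried there: the exchange brings in hydrogen-bond acceptors and loses inhibition. The data at hand offer no explanation for the size of this step. Still open, from the compounds shown here alone, is how an amine, a carboxylic acid or a longer chain would behave at this aromatic carbon. Also open, going by these compounds, is whether the same exchange would cost as much on the core of compound 1.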